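Pyrimidine in place of pyridine on the amine of compound 1

This account rests on a few compounds, and the source may have more. Where it says the series, first, only, none or still open, it means among the compounds named here.

Compound 1 `Cc1cccc(NC[C@@H]2CC3(CC3)CN2C(=O)c2nc(C)sc2-c2ccccc2)n1` stands highest of the two measured compounds: in a functional assay on CHO cells for antagonist activity at Orexin/Hypocretin receptor type 1 (Homo sapiens), read by FLIPR and calcium flux (a higher number here means a more potent compound, by a factor of ten per unit of this negative logarithm, a lower number a less potent compound), compound 1 gives 7.3, while compound 2 `O=C(c1nc(C(F)(F)F)ccc1-c1ncccn1)N1CC2(CC2)C[C@H]1CNc1ccc(C(F)(F)F)cn1` gives 6.7, a gap beyond the scatter. Compound 3 `Cc1ccnc(NC[C@@H]2CC3(CC3)CN2C(=O)c2nc(C)sc2-c2ccccc2)n1` keeps the core of compound 1 and carries 4-methylpyrimidin-2-yl in place of 6-methylpyridin-2-yl on an amine nitrogen. Among the compounds with values here, no measured pair isolates this change, so the expectation rests on compound 1 alone. A small loss, at the edge of the scatter, is the expected step of a number 0.30 log units lower from compound 1 to compound 3 (within the scatter). Compound 3 is therefore estimated at 7, within a range of 6.3 to 7.6.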

Compound 3, negative logarithm of the antagonist equilibrium constant: 6.1
Compound 3: middle estimate off by 0.90 log units, on the high side; measured number outside the range, below it.
By their numbers in this assay, from the lowest: compound 3; then compound 2; then compound 1.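

The group on the amine nitrogen is a sensitive position on the core of compound 1: with the heavy-atom count unchanged, 4-methylpyrimidin-2-yl in place of 6-methylpyridin-2-yl gives a number 1.20 log units lower from compound 1 to compound 3 (beyond the scatter) in this assay. This swap alters the ring hetero atoms and the place of the methyl together, so the step belongs to both changes at once. Nothing available accounts for the loss.

Which of the two changes carries the step remains open. Also open, from the compounds shown here alone, is how an unsubstituted pyridin-2-yl or a chloropyridin-2-yl would stand on the same amine.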